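Oxadiazole in place of the amide on the pyridazine series

The compounds below may be only part of what the source reports. "The series", "measured", "known", "first", "only" and "open" are said of these compounds alone.

Measured compounds in an assay on microsomes from liver for inhibition of acyl-CoA desaturase 1 (Rattus norvegicus); a lower number here means a stronger inhibitor, a higher number a weaker inhibitor:
compound 1, `O=C(NCCC1CC1)c1ccc(N2CCC(Oc3ccccc3C(F)(F)F)CC2)nn1`, 14 nM
compound 2, `Cc1cccc(OC2CCN(c3ccc(-n4ccnc4)nn3)CC2)c1`, 251 nM

Compound 1 gives the lowest number of the two measured compounds in this assay; compound 2 stands well apart from it, and the gap between the two lies beyond the usual scatter of repeated measurements. The two compounds differ in more than one place, so their pair says only what the two values show, nothing about any single change.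

Compound 3, `CC(C)Cc1nnc(-c2ccc(N3CCC(Oc4ccccc4C(F)(F)F)CC3)nn2)o1`, is not yet measured. It keeps the shared core of compound 1 and differs from it in one place: 5-isobutyl-1,3,4-oxadiazol-2-yl in place of (2-cyclopropylethyl)carbamoyl on an aromatic carbon. The entering group carries no hydrogen-bond donor, whereas the leaving group carries one; the entering group also brings an aromatic ring with three hetero atoms where the leaving group had a three-membered non-aromatic ring.

Among the compounds with values here, no measured pair shows this kind of change, so its size and direction in this assay cannot be read from the data. A step of modest size, toward a higher number, is expected for compound 3, though a step within the scatter would not be surprising; the expected step is a 2.1-fold higher number from compound 1 to compound 3 (0.33 log units; beyond the scatter). Compound 3 is estimated at 30 nM in this assay, with a range from 8 nM to 120 nM.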

Compound 3, half-maximal inhibitory concentration: 15 nM
Beside the measured number, compound 3's estimate is 2.0-fold (0.30 log units) above it; the measured number falls inside the stated range.
By their numbers in this assay, from the lowest: compounds 1 and 3 (each within the scatter of the next); then compound 2.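

The exchange of (2-cyclopropylethyl)carbamoyl for 5-isobutyl-1,3,4-oxadiazol-2-yl on this aromatic carbon is a 1.1-fold higher number from compound 1 to compound 3 (0.03 log units; within the scatter) in this assay, so the two compounds cannot be ordered in this assay. In this pair, a value of this order therefore does not depend on the amide hydrogen: the entering group has no hydrogen-bond donor where the leaving group has one, and it brings a five-membered aromatic ring with 3 hetero atoms where the leaving group had a three-membered non-aromatic ring of carbon only. No measured property bears on why the two groups read alike, and the finding rests on this single pair.

Still open, going by these compounds, is how much the isobutyl chain itself contributes, which a methyl or a cyclopropylmethyl group in its place on the same aromatic ring would show. Also open, on these data alone, is how far this carbon tolerates other replacements for the amide, such as a carboxylic acid or a methyl ester, and whether the exchange reads the same with the rest of compound 1 altered.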